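Swapping Chloro for Trifluoromethyl on an Aniline Arm

A few compounds are considered here, and "the series" means these few. Any claim that something is new, unique, unknown or untested is made for them only; others in the source may bear on it.

Among the measured compounds shown here, compound 3 `COc1cc(-c2nn(-c3ccccc3)cc2C(=O)/C=C\Nc2ccc(Cl)cc2)cc(OC)c1OC` is the only member of this small set that gives an actual number in a functional assay on U-87MG ATCC cells (Homo sapiens) for antiproliferative activity, read by MTT assay, with a stated time of 48 h; a higher number here means a weaker inhibitor, a lower number a stronger inhibitor: there compound 3 gives 3210 nM. Compound 1 `O=C(/C=C\Nc1ccc(C(F)(F)F)cc1)c1cn(-c2ccccc2)nc1-c1ccc(Cl)cc1` reaches only the assay limit, > 50000 nM. Compound 2 `COc1ccc(-c2nn(-c3ccccc3)cc2C(=O)/C=C\Nc2ccc(C(F)(F)F)cc2)cc1` likewise reaches only the limit, > 50000 nM. The step from compound 1 to compound 2 a step that the two limits leave unreadable from compound 1 to compound 2 is therefore unreadable, and the limit of > 50000 nM in this assay, at which 2 of the 3 values shown sit, is all that can be said of that pair.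

Compound 4 `COc1cc(-c2nn(-c3ccccc3)cc2C(=O)/C=C\Nc2ccc(C(F)(F)F)cc2)cc(OC)c1OC` differs from compound 3 in one place: trifluoromethyl in place of chloro on an aromatic carbon. For the measured compounds named here, no measured pair differs in exactly this way, so no measured step reports the size of this change directly. What the set does show is that both compounds carrying the (4-(trifluoromethyl)phenyl)amino group, compound 1 and compound 2, sit at the limit, while compound 3 with the (4-chlorophenyl)amino group gives a number; those compounds differ elsewhere as well, so the comparison is loose. On that basis a weakening beyond the scatter is expected for compound 4, with a real chance that only a limit is returned. The step from compound 3 to compound 4 is expected to be a 3.1-fold higher number from compound 3 to compound 4 (0.49 log units; beyond the scatter). In this assay compound 4 is expected to give about 10000 nM, within 3000 nM to 50000 nM.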

Compound 4, half-maximal inhibitory concentration: > 50000 nM
Compound 4: only a limit was reported; the forecaster's own chance of this, stated with the estimate: 35%; middle value at least 5.0-fold (0.69 log units) away from the limit.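

In this assay, among the compounds shown here, trifluoromethyl in place of chloro on an aromatic carbon is an at least 15-fold higher number from compound 3 to compound 4 (1.19 log units; beyond the scatter), the first measure of this change in a pair that differs in that one place alone. Compound 4 reaches only a limit, > 50000 nM, so the true size of the step may be larger than the figure shows. The 3,4,5-trimethoxyphenyl group does not bring a readable number back in the presence of the (4-(trifluoromethyl)phenyl)amino group, though the steps linking compound 4 to compound 1 and compound 2 cannot be read, because all of these values are limits: the limit of > 50000 nM in this assay, at which 3 of the 4 values shown sit.

What the compounds shown leave open is how far this loss depends on the group at the other end of the molecule, since chloro partners of compound 1 and compound 2 do not appear here. They also leave open whether a smaller change on the same aromatic carbon, such as fluoro, methyl or a nitrile, would keep a readable number like that of compound 3, or whether chloro is unusual in allowing one.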